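A few compounds are considered here, and "the series" means these few. Any claim that something is new, unique, unknown or untested is made for them only; others in the source may bear on it.

Compound 1 `O=C(CCc1cccc2c1B(O)OC2)Nc1ccc(Cl)cc1` gives 3600 nM in a functional assay on MDA-MB-231 cells (Homo sapiens) for antiproliferative activity, read by MTT assay, with a stated time of 72 h; on this read-out lower numbers stand for stronger inhibition and higher numbers for weaker inhibition. Compound 2 `COc1ccc(NC(=O)CCc2cccc3c2B(O)OC3)cc1` differs from it in a single place, (methoxy in place of chloro on an aromatic carbon), and in this assay compound 2 gives 850 nM. Compound 3 `O=C(CCc1cccc2c1B(O)OC2)Nc1cccc(-c2ccc(Cl)cc2)c1` is built on a different core; the difference between the two cores is not broken down here. In this assay compound 3 gives 260 nM, the lowest of the three numbers. Compound 4 `COc1ccc(-c2cccc(NC(=O)CCc3cccc4c3B(O)OC4)c2)cc1` is compound 3 with the same change made once more, (methoxy in place of chloro on an aromatic carbon), at the same kind of place. Because a 4.2-fold lower number from compound 1 to compound 2 (0.63 log units; beyond the scatter) was seen on the other core, a somewhat smaller step is expected here, a 2.6-fold lower number from compound 3 to compound 4 (0.41 log units; beyond the scatter). Compound 4 is therefore estimated at 100 nM in this assay, most likely between 40 nM and 250 nM.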

Compound 4, half-maximal inhibitory concentration: 88 nM
Estimate against measurement, compound 4: 1.1-fold (0.06 log units) above; measured number inside the range.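

The step of a 3.0-fold lower number from compound 3 to compound 4 (0.47 log units; beyond the scatter) in this assay goes the same way as the one seen on the core of compound 1, with methoxy in place of chloro giving the lower number. The sizes of the two steps also agree: the same change on two cores in this assay, a 4.2-fold lower number (0.63 log units; beyond the scatter) from compound 1 to compound 2 and a 3.0-fold lower number (0.47 log units; beyond the scatter) from compound 3 to compound 4, 1.4-fold (0.16 log units) apart, within the scatter of two such steps. So, for these two pairs, the change carried over from one core to the other in both direction and size, but two pairs cannot show that it would hold on every core in this series, and they do not explain why the number falls.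

The compounds shown leave open how an amine, a carboxylic acid or a longer ether such as ethoxy would compare in the same place. They also leave open whether the step would be repeated on a third core.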